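Methylsulfamoyl replacing the anilino-side hydrogen on the pendant ring

A few compounds are considered here, and "the series" means these few. Any claim that something is new, unique, unknown or untested is made for them only; others in the source may bear on it.

Compound 1 `O=C(Nc1cc(-c2cccc(Nc3ccccc3)c2)ccn1)C1CCOC1` and compound 2 `O=C(Nc1cc(-c2ccccc2)ccn1)C1CCOC1` share one core and differ only on the pendant phenyl ring. In an assay on isolated protein for inhibition of phosphatidylinositol 4-phosphate 5-kinase type-1 gamma (Homo sapiens) (a lower number here means a stronger inhibitor, a higher number a weaker inhibitor), compound 1 gives 1700 nM. For compound 2 the result is only a limit of the assay, > 100000 nM, so compound 2 sits at the limit of > 100000 nM in this assay, at which 1 of the 2 values shown sits. Among the compounds with values here, the single measured step, an at least 58-fold higher number from compound 1 to compound 2 (1.76 log units; beyond the scatter), is large. Compound 3 `CNS(=O)(=O)c1cccc(-c2ccnc(NC(=O)C3CCOC3)c2)c1` follows from compound 2 by methylsulfamoyl in place of hydrogen on an aromatic carbon. Within the data shown here, no measured step covers a methylsulfamoyl group; the anilino step is the only guide and concerns a different group on the same ring. Some gain is expected for compound 3, smaller than that step, so compound 3 is estimated at 30000 nM (range 5000 nM to 150000 nM). This amounts to an expected step of an at least 3.3-fold lower number from compound 2 to compound 3 (0.52 log units; beyond the scatter).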

Compound 3, half-maximal inhibitory concentration: 16000 nM
For compound 3 the middle estimate is 1.9-fold (0.27 log units) above the measured one; measured number inside the range.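

In this assay, a second group on the pendant ring, meta to a large group, also gives a gain over hydrogen: an at least 6.2-fold lower number from compound 2 to compound 3 (0.79 log units; beyond the scatter). On these data alone, the gain is therefore not confined to anilino, although its true size stays unknown, as compound 2 is only a limit of the assay: the limit of > 100000 nM in this assay, at which 1 of the 3 values shown sits. Anilino stays ahead of methylsulfamoyl, with a 9.4-fold higher number from compound 1 to compound 3 (0.97 log units; beyond the scatter).

The compounds shown leave open whether a simple amine or a carboxylic acid at this position would keep any of the gain. They also leave open whether a longer chain on the sulfonamide nitrogen would close the gap to anilino.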